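The compounds below may be only part of what the source reports. "The series", "measured", "known", "first", "only" and "open" are said of these compounds alone.

In a functional assay on MKN-45 cells (Homo sapiens) for inhibition, with a stated time of 72 h (on this read-out lower numbers stand for stronger inhibition and higher numbers for weaker inhibition), three compounds that share one core and differ in a single group have been measured. Compound 1 `COc1ccc(S(=O)(=O)N2CCc3cccc(-c4ccc(N)cc4)c32)cc1` gives 162 nM, compound 2 `COc1ccc(S(=O)(=O)N2CCc3cccc(-c4ccc([N+](=O)[O-])cc4)c32)cc1` gives 34 nM, and compound 3 `COc1ccc(-c2cccc3c2N(S(=O)(=O)c2ccc(OC)cc2)CC3)cc1` gives 211 nM. Two steps show where compound 3 stands. One is a 1.3-fold higher number from compound 1 to compound 3 (0.11 log units; within the scatter), which keeps it level with the amino compound, and the other is a 6.2-fold higher number from compound 2 to compound 3 (0.79 log units; beyond the scatter), which separates it from the nitro compound.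

Compound 4 `COc1ccc(S(=O)(=O)N2CCc3cccc(-c4ccccc4)c32)cc1` has hydrogen in place of methoxy on an aromatic carbon, para to a large group (hydrogen in place of methoxy on an aromatic carbon). Going by the values given here, no measured compound carries hydrogen at this place, so the measured steps bear on it only indirectly. Only the nitro group of compound 2 stands apart, with a 4.8-fold lower number from compound 1 to compound 2 (0.68 log units; beyond the scatter), a modest step. Methoxy and amino do not differ beyond the scatter, and hydrogen is not expected to stand apart as nitro does. The expected change is a 1.2-fold lower number from compound 3 to compound 4 (0.09 log units; within the scatter), which would be no step beyond the scatter. For compound 4 the estimated value is 170 nM, with an expected range from 70 nM to 400 nM.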

Compound 4, half-maximal inhibitory concentration: 117 nM
The estimate for compound 4 lay 1.5-fold (0.16 log units) above the measured number; measured number inside the range.
By their numbers in this assay, from the lowest: compound 2; then compounds 4, 1 and 3 (each within the scatter of the next).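

Taking the methoxy off altogether, so that 4-methoxyphenyl becomes phenyl, leaves the number in this assay within the scatter (a 1.8-fold lower number from compound 3 to compound 4 (0.26 log units; within the scatter)), and the same holds against the amino compound (a 1.4-fold lower number from compound 1 to compound 4 (0.14 log units; within the scatter)). The position therefore needs neither methoxy nor amino to keep this level of inhibition, and the bare ring now gives a baseline that these two groups do not measurably shift. Only nitro stands clear of that baseline (a 3.4-fold higher number from compound 2 to compound 4 (0.54 log units; beyond the scatter)), a modest step, and no measurement shown here explains why this one group differs from hydrogen.

As far as these compounds go, whether nitro is a lone case stays open, since a nitrile, a carboxylic acid or a trifluoromethyl group at this place could fall with nitro or with hydrogen. Also open, from the compounds shown here alone, is whether nitro would keep its edge on another carbon of the same ring.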